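Ethyl on the carbamoyl nitrogen: compound 3 to compound 4

This account rests on a few compounds, and the source may have more. Where it says the series, first, only, none or still open, it means among the compounds named here.

Measured so far in a functional assay on MGC-803 cells (Homo sapiens) for cytotoxicity, read by MTT assay, with a stated time of 72 h; a higher number here means a weaker inhibitor, a lower number a stronger inhibitor:
compound 1, `CCNC(=O)N1CCN(C(=S)SCc2cn(Cc3ccccc3F)nn2)CC1`, 2830 nM
compound 2, `CCNC(=O)N1CCN(C(=S)SCc2cn(Cc3ccc(F)cc3)nn2)CC1`, 2170 nM
compound 3, `NC(=O)N1CCN(C(=S)SCc2cn(Cc3ccc(Cl)cc3)nn2)CC1`, > 128000 nM

Compound 3 stands apart from the other two: in this assay compound 3 gives only a limit of the assay, > 128000 nM, and no number, so it sits at the limit of > 128000 nM in this assay, at which 1 of the 3 values shown sits. Going by the values given here, compound 1 and compound 2 both give numbers in the low micromolar range; the one step among them, a 1.3-fold lower number from compound 1 to compound 2 (0.12 log units; within the scatter), is within the scatter and concerns the halophenyl group only, not the carbamoyl nitrogen.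

Compound 4, `CCNC(=O)N1CCN(C(=S)SCc2cn(Cc3ccc(Cl)cc3)nn2)CC1`, differs from compound 3 by ethyl in place of hydrogen on an amide-type nitrogen; it carries the ethylcarbamoyl group of compound 1 and compound 2 together with the 4-chlorophenyl group of compound 3. Among the compounds with values here, no measured step touches the carbamoyl nitrogen, so the size of the move from compound 3 cannot be read from a step. What can be said is that the two ethylcarbamoyl compounds, compound 1 and compound 2, give numbers rather than a limit, with compound 2 at 2170 nM on a 4-halophenyl group.

On that basis compound 4 is expected to give a number close to those of compound 1 and compound 2, estimated at 2500 nM with a range of 800 nM to 9000 nM. The expected step, an at least 51-fold lower number from compound 3 to compound 4 (1.70 log units; beyond the scatter), is therefore a large move from a limit to a measurable value.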

Compound 4, half-maximal inhibitory concentration: 35400 nM
Estimate against measurement, compound 4: 14-fold (1.15 log units) below; measured number outside the range, above it.
By their numbers in this assay, from the lowest: compounds 2 and 1 (each within the scatter of the next); then compound 4. At a limit, above all of these: compound 3.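

In this assay, going by these compounds alone, ethyl on the amide-type nitrogen gives the first step at this position, an at least 3.6-fold lower number from compound 3 to compound 4 (0.55 log units; beyond the scatter), and its full size stays unknown. Compound 3 remains a limit of the assay and not a number: the limit of > 128000 nM in this assay, at which 1 of the 4 values shown sits.

Within the data shown here, with the ethylcarbamoyl group held constant, the halophenyl group now makes a large difference, a 16-fold higher number from compound 2 to compound 4 (1.21 log units; beyond the scatter), and likewise a 13-fold higher number from compound 1 to compound 4 (1.10 log units; beyond the scatter), whereas the only earlier step on that group, a 1.3-fold lower number from compound 1 to compound 2 (0.12 log units; within the scatter), lay within the scatter, so ethyl on this nitrogen does not by itself set the number in the low micromolar range.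

The compounds shown leave open how methyl or a longer chain such as propyl on the carbamoyl nitrogen would compare with ethyl, and whether the step from hydrogen to ethyl has a similar size when 4-fluorophenyl replaces 4-chlorophenyl. They also leave open whether bromo at the place of chloro on the aromatic carbon would follow fluoro or chloro in this assay.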